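Estimating Compound 4 from a Chlorophenyl to Methoxyphenyl Swap

The compounds below may be only part of what the source reports. "The series", "measured", "known", "first", "only" and "open" are said of these compounds alone.

Compound 1, `Cc1ccc(Nc2nc(C)c(C(=O)/C=C/c3ccc(Cl)cc3)s2)cc1`: > 25000 nM
Compound 2, `COc1cccc(/C=C/C(=O)c2sc(Nc3ccc(Cl)c(Cl)c3)nc2C)c1`: 10100 nM
Compound 3, `Cc1ccc(Nc2nc(C)c(C(=O)/C=C/c3ccccc3Cl)s2)cc1`: > 25000 nM

In a functional assay on PC-3 cells (Homo sapiens) for cytotoxicity, read by MTT assay (on this read-out lower numbers stand for stronger inhibition and higher numbers for weaker inhibition), compound 3 gives > 25000 nM, which is a limit of the assay and not a number. Compound 1 likewise gives > 25000 nM, also a limit. Compound 2 gives 10100 nM in this assay. For the measured compounds named here, the only measured step, a step that the two limits leave unreadable from compound 1 to compound 3, stays unreadable because both ends sit at the limit of > 25000 nM in this assay, at which 2 of the 3 values shown sit. Compound 4, `COc1cccc(/C=C/C(=O)c2sc(Nc3ccc(C)cc3)nc2C)c1`, differs from compound 3 by 3-methoxyphenyl in place of 2-chlorophenyl on a double-bonded chain carbon bound to a double-bonded chain carbon. Going by the values given here, no measured step mirrors this change; compound 2 carries the same 3-methoxyphenyl with a different group elsewhere on the shared core and shows only modest inhibition. Compound 4 is therefore expected to stay weak, near 20000 nM within 7000 nM to 50000 nM, so that the step of an at least 1.2-fold lower number from compound 3 to compound 4 (0.09 log units; that floor lies within the scatter) is expected to be small and possibly unreadable.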

Compound 4, half-maximal inhibitory concentration: > 25000 nM
Compound 4 gave a limit, no number (the forecaster's own chance of this, stated with the estimate: 50%); middle value at least 1.2-fold (0.09 log units) away from the limit.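

In this assay, 4-methylphenyl in place of 3,4-dichlorophenyl on a nitrogen on an aromatic ring, with 3-methoxyphenyl kept, gives an at least 2.4-fold higher number from compound 2 to compound 4 (0.39 log units; beyond the scatter). For the compounds shown here, this is the first readable step, and it shows that the group on that nitrogen changes the read-out, while 3-methoxyphenyl alone does not give compound 4 a readable value. Compound 4 stands at a limit, not a number, so its steps from compound 1 and compound 3 cannot be read: the limit of > 25000 nM in this assay, at which 3 of the 4 values shown sit.

Still open, as far as these compounds go, is whether 3,4-dichlorophenyl on the nitrogen would give a readable value alongside 2-chlorophenyl or 4-chlorophenyl. Also open, from the compounds shown here alone, is whether an amine or a carboxylic acid on the phenyl ring in place of methoxy would do so.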